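Aryl Swap on a Ring Nitrogen: Cytotoxicity Outlook

This account rests on a few compounds, and the source may have more. Where it says the series, first, only, none or still open, it means among the compounds named here.

Of the compounds shown here, three sharing a core have been tested in an ADME assay on NIH3T3 cells (Mus musculus) for cytotoxicity, read by MTT assay, with a stated time of 24 h; on this read-out higher numbers stand for weaker inhibition and lower numbers for stronger inhibition. In this assay compound 1 `O=C(CN1CCN(c2ccccc2Cl)CC1)N1CCN(c2nnc(-c3ccccc3)c(-c3ccccc3)n2)CC1` gives 350000 nM. Compound 2 `Cc1ccc(-c2nnc(N3CCN(C(=O)CN4CCN(c5ccccc5Cl)CC4)CC3)nc2-c2ccc(C)cc2)cc1` reaches only a limit of the assay, > 859000 nM, in this assay. Compound 3 `COc1cccc(N2CCN(CC(=O)N3CCN(c4nnc(-c5ccc(C)cc5)c(-c5ccc(C)cc5)n4)CC3)CC2)c1` likewise reaches only a limit, > 866000 nM, in this assay. Compound 3 thus stands at a limit, not at a number, which is where one of the three values sits in each case, as the limit of > 859000 nM in this assay, at which 1 of the 3 values shown sits, and the limit of > 866000 nM in this assay, at which 1 of the 3 values shown sits, show. Going by the values given here, the one measured step that changes the same place, a step that the two limits leave unreadable from compound 2 to compound 3, cannot be read in size for this reason.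

Compound 4 `Cc1ccc(-c2nnc(N3CCN(C(=O)CN4CCN(c5ccc(Cl)cc5)CC4)CC3)nc2-c2ccc(C)cc2)cc1` differs from compound 3 in one place: 4-chlorophenyl in place of 3-methoxyphenyl on an amine nitrogen in a ring. Among the compounds with values here, no measured step shows how a 4-chlorophenyl group at this place behaves, and the only step at this place has no readable size. The expectation is that compound 4 in this assay again sits at or near the limit of the assay, a step of an at least 1.0-fold lower number from compound 3 to compound 4 (0.03 log units; that floor lies within the scatter) that is expected to stay within the scatter. Compound 4 is estimated at 800000 nM, with a range from 350000 nM to 1700000 nM, and is most likely reported as a limit rather than a number.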

Compound 4, half-maximal inhibitory concentration: 567000 nM
Estimate against measurement, compound 4: 1.4-fold (0.15 log units) above; the measured number falls inside the stated range.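

Among compound 2, compound 3 and compound 4, which differ only in the aryl group on an amine nitrogen in a ring, compound 4 is the only one that gives a number rather than a limit in this assay. Going by these compounds alone, this allows the first readable steps at this position: the change from 3-methoxyphenyl to 4-chlorophenyl gives an at least 1.5-fold lower number from compound 3 to compound 4 (0.18 log units; that floor lies within the scatter), and the change from 2-chlorophenyl to 4-chlorophenyl gives an at least 1.5-fold lower number from compound 2 to compound 4 (0.18 log units; that floor lies within the scatter). Each of these sizes is only a floor, and that floor lies within the scatter, so a real effect of either swap is possible but not shown.

Going by these compounds, the step between compound 2 and compound 3 still cannot be read, and how far the true values of these two compounds lie from that of compound 4 also remains open. On these data alone, it is equally open whether a plain phenyl, a 4-fluorophenyl or a 4-aminophenyl group at this place would give a number or a limit.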